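Chloro for hydroxy on the benzofuran-free core: an expected step

A few compounds are considered here, and "the series" means these few. Any claim that something is new, unique, unknown or untested is made for them only; others in the source may bear on it.

In an assay on isolated protein for inhibition of protein deacetylase HDAC6 (Homo sapiens), read by fluorescence, with a stated time of 2 h (on this read-out higher numbers stand for weaker inhibition and lower numbers for stronger inhibition), compound 3, `CCCNNC(=O)c1ccc(CNC(=O)c2cc3cc(O)ccc3o2)cc1`, gives only a limit, > 10000 nM. Compound 1, `CCCNNC(=O)c1ccc(CNC(=O)c2ccc3ccccc3c2)cc1`, gives in this assay a limit as well, > 10000 nM. Compound 2, `CCCNNC(=O)c1ccc(CNC(=O)c2cnc3ccccc3c2)cc1`, also gives in this assay a limit, > 10000 nM. Compound 3 therefore stands nowhere apart from the others, since all three values sit at the same limit (the limit of > 10000 nM in this assay, at which 3 of the 3 values shown sit). Compound 4, `CCCNNC(=O)c1ccc(CNC(=O)c2cc3cc(Cl)ccc3o2)cc1`, carries chloro in place of hydroxy on an aromatic carbon. With no measured step between any two of these compounds, a step of about the size a step that the limit leaves unreadable from compound 3 to compound 4 is expected, that is none beyond the scatter. Compound 4 is estimated to give 15000 nM, within 4000 nM to 60000 nM, most likely again reported as a limit.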

Compound 4, half-maximal inhibitory concentration: > 10000 nM
Compound 4 ended at the assay's limit; the forecaster's own chance of this, stated with the estimate: 80%; the middle value lies beyond the limit too.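

No step can be read between compound 3 and compound 4, since both values are limits: the limit of > 10000 nM in this assay, at which 4 of the 4 values shown sit.

The compounds shown leave open which change to the shared core, if any, would give a measurable value in this assay.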